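The source may hold more compounds than are shown below. What is called first, only, known or untested is meant among the compounds shown, and "the series" means these compounds.

Measured compounds:
- compound 1 `c1cncc(N2CC3CC2CN3)c1` — 64.6 nM
- compound 2 `COCC[C@H]1C[C@@H]1c1cncc(N2CCCNCC2)c1` — > 10000 nM

Both were tested in an ADME assay on a protein complex for displacement of a labelled ligand from Neuronal acetylcholine receptor; alpha3/beta4 (Rattus norvegicus), read by scintillation counting; on this read-out lower numbers stand for stronger inhibition and higher numbers for weaker inhibition. Compound 1 gives 64.6 nM there. For compound 2 the result is only a limit, > 10000 nM, so no exact number is known for it; this is the limit of > 10000 nM in this assay, at which 1 of the 2 values shown sits. Compound 1 and compound 2 differ in several places at once, so nothing can be said about which part of that change matters; their two values only show that one is a number and the other a limit.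

The step now followed goes from compound 2 to compound 3 `COCC[C@@H]1C[C@H]1c1cncc(N2CCCNCC2)c1`, which has not yet been measured in this assay. The change is the two compounds have the same atoms and bonds and differ only in configuration as drawn: 2 of 2 stereo elements differ (all stereocentres are inverted: mirror images); a stereocentre at a saturated ring carbon is drawn R in compound 2 and S in compound 3; a stereocentre at a saturated ring carbon is drawn S in compound 2 and R in compound 3. With no measured pair of mirror images among these compounds, no size of step can be read off for such a change. Given that compound 2 reached only a limit, compound 3 is expected to stay in the same weak region, so the estimated step of an at least 1.1-fold lower number from compound 2 to compound 3 (0.04 log units; that floor lies within the scatter) is small, with a fair chance that compound 3 again reaches only a limit. Compound 3 is estimated at 9000 nM, within 2000 nM to 40000 nM.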

Compound 3, inhibition constant: > 10000 nM
Compound 3: a limit, no number; the forecaster's own chance of this, stated with the estimate: 65%; at least 1.1-fold (0.04 log units) between middle value and limit.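

Compound 3, like compound 2, gives only a limit and not a number, so no step between these two mirror images can be read: the limit of > 10000 nM in this assay, at which 2 of the 3 values shown sit.

The compounds shown leave open how far each mirror image lies beyond that limit, and whether inverting the configuration changes inhibition at all in this assay.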